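Extending the methyl at the aromatic nitrogen with ethoxycarbonyl

The source may hold more compounds than are shown below. What is called first, only, known or untested is meant among the compounds shown, and "the series" means these compounds.

Measured so far:
compound 1 `CCCCCCCCCCCCN(C)C(=O)Cn1cc(Cc2cnc(O)nc2)c(=O)nc1SCc1ccc(F)cc1`: 39%
compound 2 `CCCCCCCCCCCCN(C)C(=O)Cn1cc(Cc2cnc(=O)n(C)c2)c(=O)nc1SCc1ccc(F)cc1`: 32%

Within the data shown here, in a functional assay on a cell-free system (plasma, Oryctolagus cuniculus) for inhibition of platelet-activating factor acetylhydrolase (Homo sapiens), tested at 100 nM (on this read-out lower numbers stand for less inhibition and higher numbers for more inhibition at the one concentration tested (going by the name of the read-out)), compound 2 gives 32%, and the only other number, that of compound 1, lies within the scatter of it: a number 7 percentage points lower from compound 1 to compound 2 (within the scatter). Compound 3 `CCCCCCCCCCCCN(C)C(=O)Cn1cc(Cc2cnc(=O)n(CC(=O)OCC)c2)c(=O)nc1SCc1ccc(F)cc1` differs from compound 2 by ethoxycarbonyl in place of hydrogen on a saturated chain carbon bound to an aromatic nitrogen. Among the measured compounds shown here, no measured step touches this part of the molecule; the one step known, at the ring on the saturated chain carbon bound to an aromatic carbon, stayed within the scatter. For compound 3 the expected step in this assay is therefore a number 2 percentage points lower from compound 2 to compound 3 (within the scatter), none beyond the scatter. Compound 3 is estimated at 30%, between 12% and 48%.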

Compound 3, a percentage reported as inhibition, at one concentration (the size of the read-out at that concentration, not a potency): 15%
Beside the measured number, compound 3's estimate is 15 percentage points above it; measured number inside the range.
By their numbers in this assay, from the lowest: compound 3; then compounds 2 and 1 (each within the scatter of the next).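

In this assay the saturated chain carbon bound to an aromatic nitrogen proves sensitive to change: ethoxycarbonyl in place of hydrogen there gives a number 17 percentage points lower from compound 2 to compound 3 (beyond the scatter) and is the only step beyond the scatter among those shown. The earlier change, on the saturated chain carbon bound to an aromatic carbon, stayed within it. No measurement available gives a cause for this step. From the compounds shown here alone, whether the drop follows the ester or merely the longer substituent stays open. A carboxylic acid, a primary amide or a plain propyl chain at this place would separate these.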